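The source may hold more compounds than are shown below. What is called first, only, known or untested is meant among the compounds shown, and "the series" means these compounds.

Cytotoxicity in an ADME assay on BHK cells (Mesocricetus auratus) for cytotoxicity, read by MTT assay, with a stated time of 96 h (a lower number here means that less compound is tolerated, a higher number that more compound is tolerated), is followed across a set of compounds on a shared core. Compound 1 `CN1CCN(CC(=O)Nc2ccc(-c3nc4cc(C(F)(F)F)ccc4n3C)cc2)CC1` gives 16000 nM in this assay. Compound 2 `Cn1c(-c2ccc(NC(=O)CN3CCCC3)cc2)nc2cc(C(F)(F)F)ccc21` gives 27000 nM in this assay; among the three numbers in hand it stands second highest, with compound 1 nearest (a 1.7-fold higher number from compound 1 to compound 2 (0.23 log units; within the scatter)) and compound 3 furthest. Compound 3 `Cn1c(-c2ccc(N)cc2)nc2cc(C(F)(F)F)ccc21` gives 85000 nM in this assay; the steps of a 5.3-fold higher number from compound 1 to compound 3 (0.73 log units; beyond the scatter) and a 3.1-fold higher number from compound 2 to compound 3 (0.50 log units; beyond the scatter) both concern the group on a nitrogen on an aromatic ring, as does the step from compound 1 to compound 2.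

Compound 4 `O=C(CN1CCCC1)Nc1ccc(-c2nc3cc(C(F)(F)F)ccc3[nH]2)cc1` carries hydrogen in place of methyl on an aromatic nitrogen. Among the measured compounds shown here, no measured step in this set touches that position; all three concern the amide side chain and give no direct guidance. The change is small and nothing in hand points to a direction, so the step expected in this assay is no change at the digits printed from compound 2 to compound 4 (within the scatter), within the scatter. Compound 4 is therefore estimated at 27000 nM, with a range from 12000 nM to 60000 nM.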

Compound 4, half-maximal cytotoxic concentration: 29000 nM
The estimate for compound 4 lay 1.1-fold (0.03 log units) below the measured number; low and high end bracket the measured number.
By their numbers in this assay, from the lowest: compounds 1, 2 and 4 (each within the scatter of the next); then compound 3.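

Among the compounds shown here, the aromatic nitrogen of the five-membered aromatic ring had no measured step until now; with the pyrrolidin-1-yl side chain of compound 2 in place, hydrogen in place of methyl at this position gives a 1.1-fold higher number from compound 2 to compound 4 (0.03 log units; within the scatter) in this assay. The methyl on this nitrogen can therefore be removed from compound 2 without a step beyond the scatter, so this single pair shows no dependence of the number on that methyl. Nothing in hand explains this result.

The compounds shown leave open whether the same step would hold with the 4-methylpiperazin-1-yl side chain of compound 1 or with the unacylated nitrogen of compound 3. They also leave open how an ethyl group, or a longer chain ending in an amine or a carboxylic acid, would read on this aromatic nitrogen.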